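Compound 1 and a propyl group on its core

This account rests on a few compounds, and the source may have more. Where it says the series, first, only, none or still open, it means among the compounds named here.

Compound 1 `CC(=N)N1CCC(Oc2ccc3ncn(Cc4ccc5ccc(C(=N)N)cc5c4)c3c2)CC1` is the starting point of this small series. Within the data shown here, in an assay on isolated protein for inhibition of serine protease 1 (Bos taurus) (a lower number here means a stronger inhibitor, a higher number a weaker inhibitor), compound 1 gives 50 nM, the highest of the three numbers measured so far. Compound 2 `CC(=N)N1CCC(Oc2ccc3c(c2)nc(C(C)C)n3Cc2ccc3ccc(C(=N)N)cc3c2)CC1` carries isopropyl in place of that hydrogen on an aromatic carbon of the shared core, and in this assay compound 2 gives 16 nM. Compound 3 `CC(=N)N1CCC(Oc2ccc3c(c2)nc(CCC(=O)O)n3Cc2ccc3ccc(C(=N)N)cc3c2)CC1`, with 2-carboxyethyl in place of that hydrogen, gives 14 nM. Both numbers lie beyond the scatter from compound 1. Between the two substituted analogues the step is a 1.1-fold lower number from compound 2 to compound 3 (0.06 log units; within the scatter), so two quite different groups at this place leave the number essentially unchanged.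

Compound 4 `CCCc1nc2ccc(OC3CCN(C(C)=N)CC3)cc2n1Cc1ccc2ccc(C(=N)N)cc2c1` differs from compound 1 as follows: propyl in place of hydrogen on an aromatic carbon. Among the measured compounds shown here, no measured step covers exactly this change. What bears on it is that compound 2 and compound 3 show a clearly lower number than compound 1 once a carbon group replaces the hydrogen there, while the step of a 1.1-fold lower number from compound 2 to compound 3 (0.06 log units; within the scatter) suggests that the kind of group matters little. A step of similar size in the same direction is therefore expected, a 3.3-fold lower number from compound 1 to compound 4 (0.52 log units; beyond the scatter). Compound 4 is estimated to give 15 nM, within a range from 7 nM to 35 nM.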

Compound 4, inhibition constant: 6.8 nM
Beside the measured number, compound 4's estimate is 2.2-fold (0.34 log units) above it; the measured number lies below the stated range.
By their numbers in this assay, from the lowest: compound 4; then compounds 3 and 2 (each within the scatter of the next); then compound 1.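

The step of a 7.4-fold lower number from compound 1 to compound 4 (0.87 log units; beyond the scatter) shows that an unbranched propyl chain on this aromatic carbon, between two ring nitrogen atoms, is also tolerated and carries no hydrogen-bond donors or acceptors and no net charge. In this assay compound 2 gives 16 nM and compound 4 gives 6.8 nM, so these two compounds, which differ only in isopropyl and propyl, do not share the same number. The kind of carbon group at this place may therefore matter more than compounds 2 and 3 alone suggested.

Nothing available explains the difference between propyl and the other groups at this place. The compounds shown leave open how an ethyl or butyl chain, or a propyl chain ending in an amine, would read in this assay.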